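Chalcone-type boronic series: aryl ketone swap at the carbonyl

The source may hold more compounds than are shown below. What is called first, only, known or untested is meant among the compounds shown, and "the series" means these compounds.

Measured so far in a functional assay on MDA-MB-231 cells (Homo sapiens) for cytotoxicity, read by MTT assay, with a stated time of 48 h; a lower number here means a stronger inhibitor, a higher number a weaker inhibitor:
- compound 1 `O=C(/C=C/c1ccc2c(c1)B(O)OC2)c1cccs1` gives 4600 nM
- compound 2 `O=C(/C=C/c1ccc2c(c1)B(O)OC2)c1cccnc1` gives 11400 nM

Among the compounds with values here, compound 2 holds the highest number of the two measured in this assay; its nearest neighbour is compound 1, and the only measured step, a 2.5-fold higher number from compound 1 to compound 2 (0.39 log units; beyond the scatter), separates them. Nothing else is known about the series.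

Compound 3 `O=C(/C=C/c1ccc2c(c1)B(O)OC2)c1ccc(Cl)cc1` is unmeasured. It differs from compound 2 in one place: 4-chlorophenyl in place of pyridin-3-yl on a carbonyl carbon.

Within the data shown here, only one measured step bears on this change, and it does so indirectly: a 2.5-fold higher number from compound 1 to compound 2 (0.39 log units; beyond the scatter) shows that exchanging one ring on the carbonyl carbon for another moved the number by a modest amount. The change to compound 3 again replaces the ring on that carbonyl carbon, this time by a six-membered ring of carbon only with a chlorine substituent, so a step of similar size in this assay is expected, most likely back toward the number of compound 1, that is a 2.9-fold lower number from compound 2 to compound 3 (0.45 log units; beyond the scatter). Among the measured compounds shown here, the uncertainty is wide because only two compounds anchor the series.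

For compound 3 in this assay the expected value is 4000 nM, within 1500 nM to 12000 nM.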

Compound 3, half-maximal inhibitory concentration: 7900 nM
For compound 3 the middle estimate is 2.0-fold (0.30 log units) below the measured one, and the stated range covers the measured number.
By their numbers in this assay, from the lowest: compounds 1, 3 and 2 (each within the scatter of the next, the first and the last beyond it).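

In this assay the 4-chlorophenyl ring on the carbonyl carbon gives a 1.4-fold lower number from compound 2 to compound 3 (0.16 log units; within the scatter) and a 1.7-fold higher number from compound 1 to compound 3 (0.23 log units; within the scatter), so compound 3 cannot be told apart from either neighbour, although a 2.5-fold higher number from compound 1 to compound 2 (0.39 log units; beyond the scatter) still separates the other two. A ring of carbon only bearing a chlorine, with no hydrogen-bond acceptor counted for it, therefore takes the place of pyridin-3-yl or thiophen-2-yl on this carbonyl carbon without a step beyond the scatter, and the only resolved difference among the three compounds remains the one that links the thiophen-2-yl and pyridin-3-yl rings. No measurement at hand explains these numbers or ties them to any feature of the rings.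

Open questions are what part the chlorine of the 4-chlorophenyl group plays and whether any group on this carbonyl carbon moves the number well outside the narrow band seen so far. A phenyl ring carrying a dimethylamino group or a carboxylic acid, or a saturated piperidine ring in place of the aromatic ring, would test how far this band extends.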